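The source may report more compounds than this note shows. Statements on the series, on what has been measured and on what is new or still open speak of the compounds shown alone.

Compound 3 `COc1ccc(S(=O)(=O)N2CCc3cccc(NC(C)=O)c32)cc1`: 89 nM
Compound 2 `COc1ccc(S(=O)(=O)N2CCc3cccc(NS(=O)(=O)c4ccc(F)cc4)c32)cc1`: 1200 nM
Compound 1 `COc1ccc(C(=O)Nc2cccc3c2N(S(=O)(=O)c2ccc(OC)cc2)CC3)cc1`: 2600 nM

Of the compounds shown here, three with a shared core have been tested in a functional assay on KB cells (Homo sapiens) for cytotoxicity (a lower number here means a stronger inhibitor, a higher number a weaker inhibitor), differing only in the group on the nitrogen on the aromatic ring. Compound 3, which carries an acetyl there, stands at the lowest number of the three, and both steps toward it are beyond the scatter: a 13-fold lower number from compound 2 to compound 3 (1.13 log units; beyond the scatter) and a 29-fold lower number from compound 1 to compound 3 (1.47 log units; beyond the scatter). Between compounds 1 and 2 the step is smaller: a 2.2-fold lower number from compound 1 to compound 2 (0.34 log units; beyond the scatter).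

Compound 4 `COc1ccc(S(=O)(=O)N2CCc3cccc(NC(=O)N(C)c4ccccc4)c32)cc1` is the next candidate. Its change from compound 3 is methyl(phenyl)amino in place of methyl on a carbonyl carbon. The carbonyl and the amide-type nitrogen remain, but the single carbon of the methyl gives way to a group of eight heavy atoms that includes a six-membered aromatic ring of carbon only. The two large steps to compound 3 both came from removing a group bearing such a ring from that position, so the move in compound 4 runs the other way. Compound 4 is therefore expected to give a higher number in this assay, though with the acetyl carbonyl retained the step may fall short of those two; the expected step is a 9.0-fold higher number from compound 3 to compound 4 (0.95 log units; beyond the scatter). Compound 4 is estimated at 800 nM, within 250 nM to 2500 nM.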

Compound 4, half-maximal inhibitory concentration: > 10000 nM
Compound 4: a limit, no number (the forecaster's own chance of this, stated with the estimate: 5%); middle value at least 12-fold (1.09 log units) away from the limit.
By their numbers in this assay, from the lowest: compound 3; then compound 2; then compound 1. At a limit, above all of these: compound 4.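

In this assay the reading for compound 4 is a limit of the assay and not a number: the limit of > 10000 nM in this assay, at which 1 of the 4 values shown sits. With the carbonyl and the amide-type nitrogen both kept, methyl(phenyl)amino on the carbonyl carbon gives the largest rise seen at this position (an at least 110-fold higher number from compound 3 to compound 4 (2.05 log units; beyond the scatter)), so the carbonyl that compound 3 carries does not by itself secure a low number. The group also stands apart from the two other ring-bearing groups on that nitrogen, compound 4 lying beyond both the carbonyl-linked 4-methoxyphenyl (an at least 3.8-fold higher number from compound 1 to compound 4 (0.58 log units; beyond the scatter)) and the (4-fluorophenyl)sulfonyl (an at least 8.3-fold higher number from compound 2 to compound 4 (0.92 log units; beyond the scatter)), so ring-bearing groups at this position are not all alike.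

The compounds shown leave open how far the number rises for compound 4, and whether the aromatic ring or simply the larger group accounts for the change. A dimethylamino or an ethyl on the same carbonyl carbon, or a free amine in place of the acetyl, would help to separate these readings.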